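The compounds below may be only part of what the source reports. "The series", "measured", "known", "first", "only" and "open" are said of these compounds alone.

Compound 1 `CC(C)(C)C#Cc1cn([C@@H]2O[C@H](CO)[C@@H](O)[C@@H]2O)c(=O)[nH]c1=O` gives in an ADME assay on L1210/0 cells (Mus musculus) for cytotoxicity, with a stated time of 48 h (a lower number here means a stronger inhibitor, a higher number a weaker inhibitor), a value that is only a limit of the assay, > 200000 nM.
Compound 2 `CC(C)(C)C#Cc1cn([C@H]2C[C@H](O)[C@@H](CO)O2)c(=O)[nH]c1=O` gives in this assay only a limit, > 200000 nM.
Compound 3 `CCC#Cc1cn([C@@H]2O[C@H](CO)[C@@H](O)[C@@H]2O)c(=O)[nH]c1=O` gives in this assay only a limit, > 200000 nM.

Compound 4 `CCC#Cc1cn([C@H]2C[C@H](O)[C@@H](CO)O2)c(=O)[nH]c1=O` has not yet been measured in this assay. From compound 1 to compound 2 the change is hydrogen in place of hydroxy on a saturated ring carbon, and the step it made is a step that the two limits leave unreadable from compound 1 to compound 2. From compound 3 to compound 4 the same change is made, (hydrogen in place of hydroxy on a saturated ring carbon), at a place described in the same words. The two cores differ by ethyl in place of tert-butyl on a triple-bonded carbon, and that step reads a step that the two limits leave unreadable from compound 1 to compound 3. Every value here sits at the limit of > 200000 nM in this assay, at which 3 of the 3 values shown sit, so none of the steps can be read in size. The expectation for compound 4 rests on the fact that compound 3 gives > 200000 nM and on (the limit of > 200000 nM in this assay, at which 3 of the 3 values shown sit), at which all three measured compounds stand. Compound 4 is therefore expected to give 300000 nM in this assay. The step from compound 3 to compound 4 is estimated as a step that the limit leaves unreadable from compound 3 to compound 4, most likely reported once more as a limit rather than a number.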

Compound 4, half-maximal inhibitory concentration: > 200000 nM
Compound 4 was reported as a limit; the forecaster's own chance of this, stated with the estimate: 90%; the middle value lies beyond the limit too.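

In this assay compound 4 gives > 200000 nM as a limit of the assay and not a number. Its steps from compound 2 and from compound 3 cannot be read in size, so no new step is gained: the limit of > 200000 nM in this assay, at which 4 of the 4 values shown sit.
The compounds shown leave open how far each lies from that limit and whether either change shifts the value in this assay at all.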